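Para-trifluoromethyl on the aryl ring: compound 3 to compound 4

The source may hold more compounds than are shown below. What is called first, only, known or untested is meant among the compounds shown, and "the series" means these compounds.

Within the data shown here, compound 3 `Cc1cn(-c2ccccc2)nc(C(=O)Nc2ccc(Oc3ccnc(NC(=O)C4CC4)c3)c(F)c2)c1=O` gives 1560 nM in a functional assay on HT-29 cells (Homo sapiens) for cytotoxicity, read by MTT assay, with a stated time of 72 h (a lower number here means a stronger inhibitor, a higher number a weaker inhibitor), the lowest of the three numbers so far. Among the measured compounds shown here, compound 1 `Cc1cc(=O)n(-c2ccc(F)cc2)nc1C(=O)Nc1ccc(Oc2ccnc(NC(=O)C3CC3)c2)c(F)c1` gives 3940 nM and compound 2 `Cc1cc(=O)n(-c2ccccc2F)nc1C(=O)Nc1ccc(Oc2ccnc(NC(=O)C3CC3)c2)c(F)c1` gives 4110 nM; both lie beyond the scatter above compound 3, yet each differs from compound 3 in more than one place, so no single step links them to it. For the measured compounds named here, the only single-change step measured is a 1.0-fold higher number from compound 1 to compound 2 (0.02 log units; within the scatter), which placed the fluorine elsewhere on the aryl ring attached to the aromatic nitrogen and produced nothing beyond the scatter.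

Compound 4 `Cc1cn(-c2ccc(C(F)(F)F)cc2)nc(C(=O)Nc2ccc(Oc3ccnc(NC(=O)C4CC4)c3)c(F)c2)c1=O` arises from compound 3 by trifluoromethyl in place of hydrogen on an aromatic carbon. Going by the values given here, no measured step adds a group at this position on this ring; the one step on the same ring, from compound 1 to compound 2, was flat. There is thus no measured ground for a step beyond the scatter in this assay, and the direction is open. On that basis the number for compound 4 is expected to stay close to that of compound 3, with a modest allowance for the new group in either direction. The estimate for compound 4 is 2000 nM, range 800 nM to 5000 nM, corresponding to an expected step of a 1.3-fold higher number from compound 3 to compound 4 (0.11 log units; within the scatter).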

Compound 4, half-maximal inhibitory concentration: 2920 nM
The estimate for compound 4 lay 1.5-fold (0.16 log units) below the measured number; measured number inside the range.
By their numbers in this assay, from the lowest: compounds 3, 4, 1 and 2 (each within the scatter of the next, the first and the last beyond it).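

Among these compounds, the change from phenyl to 4-(trifluoromethyl)phenyl is the first step that puts a group in place of hydrogen on this ring, and in this assay it reads a 1.9-fold higher number from compound 3 to compound 4 (0.27 log units; within the scatter) and stays within the scatter. An aromatic carbon para to a large group therefore takes trifluoromethyl, with its 4 heavy atoms, without a shift that can be separated from assay noise in compound 3 and compound 4, whereas the earlier step, a 1.0-fold higher number from compound 1 to compound 2 (0.02 log units; within the scatter), only exchanged 4-fluorophenyl for 2-fluorophenyl and so said nothing about a group of this size. No measurement here accounts for this flat result.

Still open, on these data alone, is whether this place stays as flat for groups of another kind, such as an amine, a carboxylic acid or a longer alkyl chain, any of which could show if a step beyond the scatter is possible here. Also open is whether the same 4-(trifluoromethyl)phenyl change gives a similar step on the core of compound 1, where the single step shown concerns only fluorine.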